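The compounds below may be only part of what the source reports. "The series", "measured", "known", "first", "only" and "open" are said of these compounds alone.

Measured compounds:
compound 1 `Cc1cccc(N2CCN(CCCNc3nc(NCc4ccco4)c4ccccc4n3)CC2)c1C`, in a functional assay on HT-29 cells (Homo sapiens) for cytotoxicity, read by MTT assay, with a stated time of 2 days (a higher number here means a weaker inhibitor, a lower number a stronger inhibitor), compound 1 gives 840 nM
compound 2 `CCCCCNc1nc(NCc2ccco2)c2cc(F)ccc2n1`, compound 2 gives 4030 nM
compound 3 `Cc1cccc(N2CCN(CCCNc3nc(NCc4ccco4)c4cc(F)ccc4n3)CC2)c1C`, compound 3 gives 1050 nM

Compound 1 holds the lowest number of the three. Its nearest neighbour is compound 3, reached by the step of a 1.3-fold higher number from compound 1 to compound 3 (0.10 log units; within the scatter), which stays within the scatter, so the two compounds are not separated on these data. Compound 2, which carries a pentyl chain in place of the whole piperazine-bearing chain, shows a higher number, and that gap does lie beyond the scatter.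

Compound 4 `Clc1cccc(N2CCN(CCCNc3nc(NCc4ccco4)c4ccccc4n3)CC2)c1Cl` is the next compound in the series. It differs from compound 1 by 2,3-dichlorophenyl in place of 2,3-dimethylphenyl on an amine nitrogen in a ring. For the measured compounds named here, no measured step touches this aryl group: the single measured step, from compound 1 to compound 3, alters a hydrogen on the fused ring of the shared core and is itself within the scatter, so it offers no guide to the size or direction of a change on the distal aryl group. With nothing to argue for a shift, the expectation for compound 4 is a number close to that of compound 1, and the step of a 1.1-fold higher number from compound 1 to compound 4 (0.03 log units; within the scatter) is expected to stay within the scatter. Compound 4 is therefore estimated at 900 nM, with a range from 350 nM to 2300 nM.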

Compound 4, half-maximal inhibitory concentration: 3370 nM
For compound 4 the middle estimate is 3.7-fold (0.57 log units) below the measured one; measured number outside the range, above it.
By their numbers in this assay, from the lowest: compounds 1 and 3 (each within the scatter of the next); then compounds 4 and 2 (each within the scatter of the next).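

In this assay, for the compounds shown here, the aryl group on an amine nitrogen in the six-membered non-aromatic ring proves to be a position that responds, with a 4.0-fold higher number from compound 1 to compound 4 (0.60 log units; beyond the scatter), whereas the only earlier step between closely matched compounds, on the shared core, stayed within the scatter. The two groups match in heavy-atom count, in their carbon-only aromatic ring, and in having no hydrogen-bond donors, acceptors or net charge, yet replacing 2,3-dimethylphenyl with 2,3-dichlorophenyl still moves the number beyond the scatter, so these shared counts do not by themselves fix the result at this position. No measurement on these groups accompanies the result, so the data give no reason for the step.

As far as these compounds go, only these two aryl groups appear at this position, so it remains open whether an unsubstituted phenyl, a methoxyphenyl or a pyridine ring there would sit nearer compound 1 or compound 4. From the compounds shown here alone, it is also open whether fluoro in place of hydrogen on the shared core would stay within the scatter when 2,3-dichlorophenyl is the aryl group.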